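The source may hold more compounds than are shown below. What is called first, only, known or untested is meant among the compounds shown, and "the series" means these compounds.

Two close relatives have been tested so far in a functional assay on L5178Y cells (Mus musculus) for antiproliferative activity, read by MTT assay; a higher number here means a weaker inhibitor, a lower number a stronger inhibitor. In this test, compound 2 `CC(C)(C)c1ccc(OCCCCN2CCN(c3ncccn3)CC2)cc1` gives 11.3 nM, while compound 1 `CCC(C)(C)c1ccc(OCCCCN2CCN(c3cccnc3)CC2)cc1` gives 3.23 nM. Compound 2 therefore has the higher number and is the weaker inhibitor of the pair, and the gap lies beyond the usual scatter of repeat measurements. These two compounds differ in more than one place, however, so their gap cannot be pinned on any single group.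

Compound 3 `CCC(C)(C)c1ccc(OCCCCN2CCN(c3ncccn3)CC2)cc1` has not yet been measured. It differs from compound 2 by one small edit: methyl in place of hydrogen on a saturated chain carbon, two bonds along the chain from an aromatic carbon. In words, a methyl replaces a hydrogen on a saturated chain carbon, two bonds along the chain from an aromatic carbon, turning tert-butyl into 1,1-dimethylpropyl. Compound 1 carries that same 1,1-dimethylpropyl group and reads 3.23 nM, which hints at a move toward a lower number. For the measured compounds named here, with no measured single-change step to go on, the expected shift is small and may not clear the scatter, an estimated 1.5-fold lower number from compound 2 to compound 3 (0.18 log units; within the scatter). For compound 3 the expected value in this assay is 7.5 nM, within an estimated range of 3 nM to 18 nM.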

Compound 3, half-maximal inhibitory concentration: 17.7 nM
Compound 3: the middle estimate sits 2.4-fold (0.37 log units) below what was measured, and the stated range covers the measured number.
By their numbers in this assay, from the lowest: compound 1; then compounds 2 and 3 (each within the scatter of the next).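

In this assay the change from tert-butyl to 1,1-dimethylpropyl gives a 1.6-fold higher number from compound 2 to compound 3 (0.19 log units; within the scatter) and so cannot be told apart from repeat-measurement noise, at least while pyrimidin-2-yl sits on the amine nitrogen in a ring. For the compounds shown here, with 1,1-dimethylpropyl held fixed, placing pyrimidin-2-yl where pyridin-3-yl stood gives a 5.5-fold higher number from compound 1 to compound 3 (0.74 log units; beyond the scatter) and is the only single-place step here that clears the scatter, which makes the group on that nitrogen, rather than the added methyl, the change that registers in these compounds. Nothing measured alongside these numbers explains either step.

Still open, as far as these compounds go, is whether the methyl step would also stay within the scatter with pyridin-3-yl on that nitrogen, as a tert-butyl partner of compound 1 would show. Also open, from the compounds shown here alone, is how other groups would read, such as cyclohexyl in place of 1,1-dimethylpropyl or pyridin-4-yl or phenyl on the amine nitrogen in a ring, as two groups on that nitrogen and two on the chain are too few to show a trend at either place.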